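The compounds below may be only part of what the source reports. "The series", "measured", "known", "first", "only" and "open" are said of these compounds alone.

Working notes on a small cytotoxicity series

Three compounds have been run so far. Compound 1 `C=C[C@@](C)(/C=C/c1ccc(OCc2cn(-c3ccc(Cl)cc3)nn2)cc1)CCC=C(C)C` and compound 2 `C=C[C@@](C)(/C=C/c1ccc(OCc2cn(-c3ccc(OC)cc3)nn2)cc1)CCC=C(C)C` share a core and differ only in one place. Compound 3 `C=C[C@@](C)(/C=C/c1ccc(OC(=O)c2cc3cc(Cl)ccc3[nH]2)cc1)CCC=C(C)C` carries a different core; the difference between the core of compound 1 and the core of compound 3 is not broken down here. The assay is a toxicity assay on RAW264.7 cells (Mus musculus) for cytotoxicity, read by MTT assay, with a stated time of 24 h; a lower number here means a stronger inhibitor, a higher number a weaker inhibitor. In this assay compound 1 gives 47600 nM, compound 2 gives 47400 nM and compound 3 gives 110000 nM.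

Among the measured compounds shown here, the one counted step, methoxy in place of chloro on an aromatic carbon, yields a 1.0-fold lower number from compound 1 to compound 2 (0.00 log units; within the scatter). For the measured compounds named here, compound 3 gives the highest of the three numbers; against compound 1 and compound 2 its values lie beyond the scatter, so this is a real gap, though no single-place step links the two cores.

Compound 4 `C=C[C@@](C)(/C=C/c1ccc(OC(=O)c2cc3cc(OC)ccc3[nH]2)cc1)CCC=C(C)C` has not been measured. It differs from compound 3 by methoxy in place of chloro on an aromatic carbon. This is the same kind of change as that from compound 1 to compound 2, but not the same: in the earlier pair the place is on an aromatic carbon of a six-membered aromatic ring of carbon only, para to a large group, whereas here the ring is part of a fused or bridged system of two rings, meta to a fused ring and para to a fused ring.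

The expectation rests on compound 1 and compound 2, whose step a 1.0-fold lower number from compound 1 to compound 2 (0.00 log units; within the scatter) fell within the scatter; a step of about no change at the digits printed from compound 3 to compound 4 (within the scatter) is therefore expected for this pair. On that basis compound 4 is estimated at 110000 nM in this assay, with the range 60000 nM to 200000 nM expected to hold most repeat measurements.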

Compound 4, half-maximal inhibitory concentration: 329000 nM
Compound 4: the middle estimate sits 3.0-fold (0.48 log units) below what was measured; the whole stated range lies below it.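

In this assay, methoxy in place of chloro does not behave as a portable change in this series, and the core carrying it matters to the size of the step: the same change on two cores in this assay, a 1.0-fold lower number (0.00 log units; within the scatter) from compound 1 to compound 2 and a 3.0-fold higher number (0.48 log units; beyond the scatter) from compound 3 to compound 4, 3.0-fold (0.48 log units) apart, beyond the scatter of two such steps. On the core of compound 3 the change gives a 3.0-fold higher number from compound 3 to compound 4 (0.48 log units; beyond the scatter), a modest step, so the flat result on the core of compound 1 cannot be taken as a general rule for this swap across the series. Among the compounds shown here, this rests on a single pair per core and shows only that the two steps differ, not what drives the difference: the two cores differ in more than one respect, and on the core of compound 3 the change sits on a ring that is part of a fused or bridged system of two rings, so neither the ring that carries the change nor the rest of the core can be singled out.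

As far as these compounds go, it remains open whether other groups on this aromatic carbon, such as fluoro, hydroxyl or an amine, would separate the two cores in the same way. Also open, from the compounds shown here alone, is whether the same split would appear with a carboxylic acid or a longer chain in place of methoxy, on either core.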